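One ring swapped on a shared core

This account rests on a few compounds, and the source may have more. Where it says the series, first, only, none or still open, it means among the compounds named here.

Measured in a functional assay on K562 cells (Homo sapiens) for antiproliferative activity, with a stated time of 72 h; a higher number here means a weaker inhibitor, a lower number a stronger inhibitor:
- compound 1 `OC[C@H]1O[C@@H](n2cnc3c(NCc4ccc(F)cc4)ncnc32)[C@H](O)[C@@H]1O`: 2700 nM
- compound 2 `COc1cccc(CNc2ncnc3c2ncn3[C@@H]2O[C@H](CO)[C@@H](O)[C@H]2O)c1OC`: > 166000 nM
- compound 3 `OC[C@H]1O[C@@H](n2cnc3c(NCc4ccc(F)c(Cl)c4)ncnc32)[C@H](O)[C@@H]1O`: 5500 nM

The reading for compound 2 is a limit of the assay and not a number. Of the two exact values in this assay, compound 3 has the higher, at 5500 nM. Its nearest neighbour is compound 1, and the chloro group accounts for a 2.0-fold higher number from compound 1 to compound 3 (0.31 log units; beyond the scatter).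

In compound 4 `Cc1ccc(O)c(CNc2ncnc3c2ncn3[C@@H]2O[C@H](CO)[C@@H](O)[C@H]2O)c1`, 2-hydroxy-5-methylphenyl stands in place of 3-chloro-4-fluorophenyl on a saturated chain carbon bound to a nitrogen on an aromatic ring: 2-hydroxy-5-methylphenyl in place of 3-chloro-4-fluorophenyl on a saturated chain carbon bound to a nitrogen on an aromatic ring. The chloro step bears on this only weakly, since the entering ring carries neither chloro nor fluoro. Closer is the other measured exchange of a whole ring, which gave an at least 30-fold lower number from compound 2 to compound 3 (1.47 log units; beyond the scatter). The matching exchange with the fluoro ring gave an at least 61-fold higher number from compound 1 to compound 2 (1.78 log units; beyond the scatter). Within the data shown here, both are large, but compound 2 is the only comparison with oxygen on the ring, and its substituents differ from those of compound 4. A clear move to a higher number is therefore expected, probably smaller than those steps. The expected step is a 3.6-fold higher number from compound 3 to compound 4 (0.56 log units; beyond the scatter).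

For compound 4 the estimated value is 20000 nM, with an expected range from 3000 nM to 120000 nM.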

Compound 4, half-maximal inhibitory concentration: 16500 nM
For compound 4 the middle estimate is 1.2-fold (0.08 log units) above the measured one; the range from low to high includes it.
By their numbers in this assay, from the lowest: compound 1; then compound 3; then compound 4. At a limit, above all of these: compound 2.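

An oxygen-bearing ring at this place need not push the number to the assay limit: the 2-hydroxy-5-methylphenyl exchange gives a 3.0-fold higher number from compound 3 to compound 4 (0.48 log units; beyond the scatter) and, measured against the fluoro ring, a 6.1-fold higher number from compound 1 to compound 4 (0.79 log units; beyond the scatter), both of them modest. Against the dimethoxy ring the same place gives an at least 10-fold lower number from compound 2 to compound 4 (1.00 log units; beyond the scatter), so among the compounds shown the large earlier steps go with the 2,3-dimethoxyphenyl ring in particular and not with oxygen on the ring as such. That last step is only a bound, since the reading for compound 2 is a limit of the assay and not a number: the limit of > 166000 nM in this assay, at which 1 of the 4 values shown sits.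

What the hydroxy and the methyl each contribute stays unresolved, as the two enter together in compound 4 and neither appears alone on the ring in the compounds shown. Also open, going by these compounds, is whether an amine or a carboxylic acid on this ring, or a longer chain at this place, would keep the number near that of compound 1 at 2700 nM or move it well away from that value.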